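Changing the ring group on an aromatic nitrogen

This account rests on a few compounds, and the source may have more. Where it says the series, first, only, none or still open, it means among the compounds named here.

In a functional assay on MDA-MB-435 cells (Homo sapiens) for cytotoxicity (a lower number here means a stronger inhibitor, a higher number a weaker inhibitor), compound 1 `C[C@@H]1O[C@@H](n2c3ccccc3c3c4c(c5c6ccccc6ccc5c32)C(=O)NC4=O)[C@H](O)[C@H](O)[C@H]1O` gives 3600 nM while compound 2 `O=C1NC(=O)c2c1c1c3ccccc3ccc1c1c2c2ccccc2n1[C@H]1OC[C@@H](O)[C@@H](O)[C@H]1O` gives 3300 nM as its value, so compound 2 stands level with compound 1 within the usual scatter. Compound 3 `O=C1NC(=O)c2c1c1c3ccccc3ccc1c1c2c2ccccc2n1[C@@H]1O[C@H](CO)[C@@H](O)[C@H](O)[C@H]1O` keeps the shared core, and its change from compound 2 is a group of 11 heavy atoms (6 carbon, 5 oxygen; one six-membered non-aromatic ring with 1 hetero atom) in place of a group of 9 heavy atoms (5 carbon, 4 oxygen; one six-membered non-aromatic ring with 1 hetero atom), on an aromatic nitrogen in the same place. The entering group is named 3,4,5-trihydroxy-6-(hydroxymethyl)oxan-2-yl. For the measured compounds named here, the one measured step that bears on this is a 1.1-fold lower number from compound 1 to compound 2 (0.04 log units; within the scatter) and it also swapped a ring group on that nitrogen. No step beyond the scatter is therefore expected in this assay and neither direction is favoured, although a single step is thin evidence. The estimated change is a 1.1-fold lower number from compound 2 to compound 3 (0.04 log units; within the scatter) and it is expected to stay small. Compound 3 is expected to give about 3000 nM with an estimated range from 1000 nM to 9000 nM in this measurement.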

Compound 3, half-maximal inhibitory concentration: 3500 nM
Compound 3: middle estimate off by 1.2-fold (0.07 log units), on the low side, within the range that was stated.
By their numbers in this assay, from the lowest: compounds 2, 3 and 1 (each within the scatter of the next).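

With 3,4,5-trihydroxy-6-(hydroxymethyl)oxan-2-yl on the aromatic nitrogen, this assay gives a 1.1-fold higher number from compound 2 to compound 3 (0.03 log units; within the scatter), and the comparison with 3,4,5-trihydroxy-6-methyloxan-2-yl gives a 1.0-fold lower number from compound 1 to compound 3 (0.01 log units; within the scatter). All three ring groups at this position therefore stand level, even though they differ in heavy-atom count, and exchanging the methyl of compound 1 for the hydroxymethyl of compound 3 leaves the number within the scatter. No measurement here explains why these numbers stay level.

All three groups are six-membered non-aromatic rings carrying hydroxyl groups, so the compounds leave open whether a different kind of group on this nitrogen, such as a simple methyl, an amine-bearing chain or a carboxylic acid, would shift the number beyond the scatter. On these data alone, whether these groups also stand level in other cell lines remains open too.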